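Swapping an aryl for a benzyl on a thiosemicarbazide nitrogen

A few compounds are considered here, and "the series" means these few. Any claim that something is new, unique, unknown or untested is made for them only; others in the source may bear on it.

Of the compounds shown here, three sharing a thiosemicarbazone-type linkage have been tested in a functional assay on HT-29 cells (Homo sapiens) for antiproliferative activity, read by sulforhodamine B assay, with a stated time of 72 h; on this read-out higher numbers stand for weaker inhibition and lower numbers for stronger inhibition. Compound 1, `Fc1cccc(NC(=S)N/N=C/c2ccc3ccccc3n2)c1`, gives 74700 nM, the highest of the three numbers and therefore the weakest inhibition recorded here. Compound 3, `CC(C)c1cccc(C(C)C)c1NC(=S)N/N=C/c1ccc2ccccc2n1`, gives 20700 nM, a lower number than compound 1 by a margin beyond the scatter. Compound 2, `CN(C)C(=S)N/N=C/c1cnc2ccccc2n1`, gives 450 nM, far lower than compound 1 and again well beyond the scatter. Compound 1 thus stands at the weak end of what has been measured, with both other compounds clearly stronger.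

The untested compound 4, `S=C(NCc1ccccc1)N/N=C/c1ccc2ccccc2n1`, keeps the core of compound 1 and alters a single group: benzyl in place of 3-fluorophenyl on an amide-type nitrogen. Going by the values given here, no pair of measured compounds differs in this one place alone, so the direction of this change cannot be read off a directly comparable pair. The measured values do show that substituents at the amide-type nitrogen are compatible with a wide spread of potencies. A modest move toward stronger inhibition is expected, the step of a 3.0-fold lower number from compound 1 to compound 4 (0.48 log units; beyond the scatter) being an estimate rather than a measured result. In this assay compound 4 is expected to give about 25000 nM, within a range from 4000 nM to 120000 nM.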

Compound 4, half-maximal inhibitory concentration: 75700 nM
Compound 4: the middle estimate sits 3.0-fold (0.48 log units) below what was measured; the measured number falls inside the stated range.
By their numbers in this assay, from the lowest: compound 2; then compound 3; then compounds 1 and 4 (each within the scatter of the next).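

Going by these compounds alone, this is the one pair here that differs in a single place, and in this assay it gives a 1.0-fold higher number from compound 1 to compound 4 (0.01 log units; within the scatter) for benzyl in place of 3-fluorophenyl on an amide-type nitrogen. The two groups are the same size by heavy-atom count and each carries one six-membered aromatic ring of carbon only, so at this position, with this core, exchanging one for the other leaves the two numbers indistinguishable. Nothing available explains why the swap makes no measurable difference.

This single pair cannot separate the two parts of the swap, the loss of the fluorine and the gain of a carbon, so each might matter little on its own or the two might cancel out. Also open, on these data alone, is how this nitrogen would respond to a different kind of group, such as a phenethyl chain, which is longer than benzyl, or a carboxylic acid on the benzyl ring.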